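The source may report more compounds than this note shows. Statements on the series, on what has been measured and on what is new or still open speak of the compounds shown alone.

Measured so far:
Compound 1 `CN(Cc1ccccc1)Cc1ncnc2c1ncn2[C@@H]1O[C@H](CO)[C@@H](O)[C@H]1O`: in a functional assay on Huh-7 cells (Homo sapiens) for cytotoxicity, read by MTT assay, with a stated time of 3 days (on this read-out lower numbers stand for higher toxicity in this test and higher numbers for lower toxicity in this test), compound 1 gives 9000 nM.
Compound 2 `OC[C@H]1O[C@@H](n2cnc3c(CSc4ccccc4)ncnc32)[C@H](O)[C@@H]1O`: in this assay compound 2 is reported only as a limit, > 100000 nM.
Compound 3 `O=C1CCCN1Cc1ncnc2c1ncn2[C@@H]1O[C@H](CO)[C@@H](O)[C@H]1O`: in this assay compound 3 gives 45000 nM.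

Compound 2 thus stands at the limit (the limit of > 100000 nM in this assay, at which 1 of the 3 values shown sits), the highest number among the three. The steps of an at least 11-fold higher number from compound 1 to compound 2 (1.04 log units; beyond the scatter), an at least 2.2-fold lower number from compound 2 to compound 3 (0.34 log units; beyond the scatter) and a 5.0-fold higher number from compound 1 to compound 3 (0.70 log units; beyond the scatter) all change the group on the saturated chain carbon. Compound 4 `OC[C@H]1O[C@@H](n2cnc3c(CSc4nc5ccccc5s4)ncnc32)[C@H](O)[C@@H]1O` differs from compound 2 in another place: 1,3-benzothiazol-2-yl in place of phenyl on a sulfur. For the measured compounds named here, no measured step touches the group on the sulfur, so there is no direct precedent. Compound 2 already sits at the limit while compounds 1 and 3 lie lower. Compound 4 is therefore expected to stay near that limit, with a step of a number no higher from compound 2 to compound 4 (the limit leaves the size open) expected to be small. Compound 4 is estimated at 100000 nM, between 30000 nM and 300000 nM.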

Compound 4, half-maximal cytotoxic concentration: > 100000 nM
Compound 4: no number, only a limit; the forecaster's own chance of this, stated with the estimate: 60%; the middle value lies on the limit itself.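

Compound 2 and compound 4 are both reported only as limits, so the step between them cannot be read: the limit of > 100000 nM in this assay, at which 2 of the 4 values shown sit. The compounds shown leave open whether 1,3-benzothiazol-2-yl in place of phenyl on a sulfur changes the number in this assay at all.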